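A few compounds are considered here, and "the series" means these few. Any claim that something is new, unique, unknown or untested is made for them only; others in the source may bear on it.

In a toxicity assay on MT4 cells (Homo sapiens) for cytotoxicity, read by MTT assay, with a stated time of 5 days (on this read-out lower numbers stand for higher toxicity in this test and higher numbers for lower toxicity in this test), three compounds have been measured. Compound 1 (`Cc1cnc(Nc2ccc(C#N)cc2)nc1Nc1c(F)cc(-c2ccco2)cc1F`) gives 8100 nM on this read-out, compound 2 (`Cc1cc(-c2ccco2)cc(C)c1Nc1ccnc(Nc2ccc(C#N)cc2)n1`) gives 1700 nM and compound 3 (`Cc1cc(-c2cccs2)cc(C)c1Nc1ccnc(Nc2ccc(C#N)cc2)n1`) gives 10000 nM on the same scale. The values of compound 3 and compound 1 lie within the scatter of each other. For the measured compounds named here, the one measured step that bears on what follows is a 5.9-fold higher number from compound 2 to compound 3 (0.77 log units; beyond the scatter) and it brings thiophen-2-yl in place of furan-2-yl on an aromatic carbon.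

The next compound is compound 4 (`Cc1cc(-c2cncnc2)cc(C)c1Nc1ccnc(Nc2ccc(C#N)cc2)n1`), which carries pyrimidin-5-yl in place of thiophen-2-yl on that aromatic carbon. The difference from compound 3 is this: pyrimidin-5-yl in place of thiophen-2-yl on an aromatic carbon and the rest of the structure stays the same. Going by the values given here, the single measured step gives a scale for such an exchange, but it is no direct precedent for pyrimidin-5-yl. Compound 2, with furan-2-yl, stands at 1700 nM on the lower side of compound 3, so a move down seems likelier than a move up, though this rests on one comparison. The expected change is a 2.2-fold lower number from compound 3 to compound 4 (0.35 log units; beyond the scatter) in this assay and it is a modest step at most. The estimate for compound 4 is 4500 nM with an expected range from 1300 nM to 15000 nM in this measurement.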

Compound 4, half-maximal cytotoxic concentration: 6800 nM
Estimate against measurement, compound 4: 1.5-fold (0.18 log units) below; measured number inside the range.
By their numbers in this assay, from the lowest: compound 2; then compounds 4, 1 and 3 (each within the scatter of the next).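

In this assay, the exchange of thiophen-2-yl for pyrimidin-5-yl, on the aromatic carbon para to a large group and meta to two methyl groups, gives no readable change (a 1.5-fold lower number from compound 3 to compound 4 (0.17 log units; within the scatter)), even though a five-membered aromatic ring with 1 hetero atom gives way to a six-membered one with 2 hetero atoms. The comparison with furan-2-yl shows something the thiophene pair alone could not: a 4.0-fold higher number from compound 2 to compound 4 (0.60 log units; beyond the scatter) lies beyond the scatter, so among these three groups at this position, furan-2-yl in compound 2 alone stands apart, with the lowest number, while compound 3 and compound 4 cannot be told apart. Nothing measured here accounts for this separation of furan-2-yl from the other two rings.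

The compounds shown leave open whether any other group on this carbon, such as a plain phenyl ring, a morpholine ring, an aminomethyl group or a carboxylic acid, would reach the number of compound 2 or move away from it. They also leave open whether pyrimidin-5-yl would behave the same way on the core of compound 1.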